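Swapping Fluorine for Bromine on the Outer Phenyl Ring

This account rests on a few compounds, and the source may have more. Where it says the series, first, only, none or still open, it means among the compounds named here.

Compound 1, `Brc1cn2ccnc2c(-c2ccc3ncn(C4CCCCC4)c3c2)n1`: 10.2%
Compound 2, `O=Cc1ccc(-c2cn3ccnc3c(-c3ccc4ncn(C5CCCCC5)c4c3)n2)cc1`: 27.8%
Compound 3, `Fc1ccc(-c2cn3ccnc3c(-c3ccc4ncn(C5CCCCC5)c4c3)n2)cc1`: 9.82%

In a functional assay on SK-MEL-2 cells (Homo sapiens) for inhibition, read by sulforhodamine B assay, with a stated time of 48 h, tested at 10 uM (on this read-out higher numbers stand for more inhibition at the one concentration tested (going by the name of the read-out) and lower numbers for less inhibition), compound 3 gives the lowest of the three numbers, but it lies within the scatter of compound 1 (a number 0.4 percentage points lower from compound 1 to compound 3 (within the scatter)) and clearly under compound 2 (a number 18 percentage points lower from compound 2 to compound 3 (beyond the scatter)). Compound 4, `Brc1ccc(-c2cn3ccnc3c(-c3ccc4ncn(C5CCCCC5)c4c3)n2)cc1`, differs from compound 3 in one place: bromo in place of fluoro on an aromatic carbon. Among the measured compounds shown here, no measured step exchanges one halogen for another on this ring. For the measured compounds named here, the only step at this position, formyl to fluoro, was the modest drop already mentioned, and the step from bromo on the core to 4-fluorophenyl moved nothing beyond the scatter. A step of a number 3.2 percentage points higher from compound 3 to compound 4 (within the scatter) is therefore expected, within the scatter. Compound 4 is estimated at 13%, between 2% and 26%.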

Compound 4, a percentage reported as inhibition, at one concentration (the size of the read-out at that concentration, not a potency): 24.1%
Estimate against measurement, compound 4: 11.1 percentage points below; the range from low to high includes it.
By their numbers in this assay, from the lowest: compounds 3 and 1 (each within the scatter of the next); then compounds 4 and 2 (each within the scatter of the next).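

In this assay, among the compounds shown here, the choice of halogen on the outer phenyl ring turns out to matter, as the first direct exchange of one halogen for another at this place gives a step beyond the scatter (a number 14.3 percentage points higher from compound 3 to compound 4 (beyond the scatter)). The 4-bromophenyl group also separates from bromo on the core (a number 13.9 percentage points higher from compound 1 to compound 4 (beyond the scatter)), whereas bromo and formyl on the ring cannot be told apart (a number 3.7 percentage points lower from compound 2 to compound 4 (within the scatter)). Nothing available explains the gap between fluoro and bromo. From the compounds shown here alone, whether chloro, an amine or a carboxylic acid at this place would read like fluoro or like bromo remains open.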